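A Phenyl Replaces Hydrogen on the Shared Core

A few compounds are considered here, and "the series" means these few. Any claim that something is new, unique, unknown or untested is made for them only; others in the source may bear on it.

Of the compounds shown here, two have been measured in a functional assay on the whole organism (Cricetulus griseus) with Cricetinae gen. sp. as the target; a higher number here means that more compound is needed for the effect, a lower number that less compound is needed. Compound 1 `CCc1ccccc1-c1n[nH]c(-c2ccccc2)n1` gives 5 mg/kg in this assay, and compound 2 `CCc1ccccc1-c1n[nH]c(-c2ccc(OC)cc2)n1` gives 5 mg/kg. Within the data shown here, compound 1 therefore stands level with compound 2, its only measured neighbour, and the step of no change at the digits printed from compound 1 to compound 2 (within the scatter) shows that putting a methoxy in place of hydrogen on an aromatic carbon left the dose unchanged within the scatter.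

Compound 3 `CCc1ccccc1-c1n[nH]c(-c2cccc(-c3ccccc3)c2)n1` has not yet been measured. It differs from compound 1 by phenyl in place of hydrogen on an aromatic carbon. Among the measured compounds shown here, the only measured step that swaps a hydrogen on an aromatic carbon for another group is no change at the digits printed from compound 1 to compound 2 (within the scatter), and that step was flat. A phenyl is a larger group than a methoxy, so the earlier step is an imperfect guide, but it offers no reason to expect a move beyond the scatter in either direction. For compound 3 the expected dose in this assay is 5 mg/kg, with a range from 2 mg/kg to 12 mg/kg. The step of no change at the digits printed from compound 1 to compound 3 (within the scatter) that this estimate implies is expected to stay within the scatter.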

Compound 3, dose for half-maximal effect: 10 mg/kg
For compound 3 the middle estimate is 2.0-fold (0.30 log units) below the measured one, and the stated range covers the measured number.
By their numbers in this assay, from the lowest: compounds 1, 2 and 3 (each within the scatter of the next).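

In this assay, a phenyl in place of hydrogen gives a 2.0-fold higher number from compound 1 to compound 3 (0.30 log units; within the scatter). This shows that a much bulkier group than the methoxy of compound 2, a whole six-membered aromatic ring of 6 heavy atoms, can sit on this aromatic carbon, meta to a large group, and the dose needed in the whole animal still cannot be told apart from that of compound 1. No measurement at hand explains this outcome, so the result describes what the dose did and gives no reason for it.

The phenyl brings no hydrogen-bond donors or acceptors and no net charge, so these compounds leave open how an amine or a carboxylic acid would fare on this same carbon. They also leave open whether a longer chain such as butyl would keep the dose within the scatter of compound 1, and whether a phenyl on a different carbon of that ring would do the same.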